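Adding a Third Methoxy Group: Expected Cytotoxicity Unchanged

The compounds below may be only part of what the source reports. "The series", "measured", "known", "first", "only" and "open" are said of these compounds alone.

The compounds here share one core; only the groups on a six-membered aromatic ring of carbon only, hanging from that core, change. Compound 1 `COc1ccc(Cn2cnc3c(N(C)c4ccc(OC)cc4)ncnc32)cc1` carries a single methoxy group on that ring, and in an ADME assay on HT-22 cells (Mus musculus) for cytotoxicity, read by MTT assay, with a stated time of 48 h (on this read-out higher numbers stand for lower toxicity in this test and lower numbers for higher toxicity in this test), compound 1 has "not determined" (no result reported). Compound 2 `COc1ccc(N(C)c2ncnc3c2ncn3Cc2ccc(OC)c(OC)c2)cc1` carries two methoxy groups. In this assay compound 2 gives > 100000 nM, which is a limit of the measurement rather than a number. Compound 2 thus stands at the limit of > 100000 nM in this assay, at which 1 of the 2 values shown sits. Compound 3 `COc1ccc(N(C)c2ncnc3c2ncn3Cc2cc(OC)c(OC)c(OC)c2)cc1` is the next step: methoxy in place of hydrogen on an aromatic carbon. Within the data shown here, no step between two measured compounds exists in this set, so nothing shows what such a change does here, and compound 1, lacking a result, gives no guidance either. The expectation is that the step that the limit leaves unreadable from compound 2 to compound 3 stays within the usual scatter, with no change in either direction. Compound 3 is therefore estimated at 150000 nM, with a range from 60000 nM to 400000 nM, and the measurement is expected most likely to report only a limit again.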

Compound 3, half-maximal cytotoxic concentration: 23000 nM
Compound 3: the middle estimate sits 6.5-fold (0.81 log units) above what was measured, outside the stated range (below it).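

Placing a methoxy group on this ring carbon, ortho to a methoxy group, meta to a second methoxy group and meta to a large group, does change the result in this assay: the change gives an at least 4.3-fold lower number from compound 2 to compound 3 (0.63 log units; beyond the scatter), and a lower number here stands for higher toxicity in this test. Among these compounds, this is the first step in the set that can be read at all, and it shows that the third methoxy group moves the read-out beyond the usual scatter, with compound 3 giving 23000 nM, a real number rather than a limit. The printed size of the step is only a lower bound, because compound 2 gives a limit of the measurement and not a number: the limit of > 100000 nM in this assay, at which 1 of the 3 values shown sits.

With compound 1 at "not determined" (no result reported), what the second methoxy group does on this ring cannot be read, so the compounds shown do not tell whether toxicity rises with each added methoxy group. They also leave open whether this change is specific to methoxy, since a hydroxyl group, a fluorine atom or an ethoxy group at the same ring carbon does not appear among them.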